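Plasma stability notes: dipropylamino to dibutylamino

A few compounds are considered here, and "the series" means these few. Any claim that something is new, unique, unknown or untested is made for them only; others in the source may bear on it.

Three compounds carry numbers in an ADME assay on a cell-free system (plasma, Homo sapiens) for metabolic stability; on this read-out lower numbers stand for a shorter-lived compound and higher numbers for a longer-lived compound. Compound 1 `CCCC(CCC)C(=O)OCN(C)C(=O)c1ccccc1` gives 6.4 h. Compound 3 `CCOC(=O)CNC(=O)OCOC(=O)C(C)(C)Oc1ccc(Cl)cc1` gives 0.0272 h. Compound 2 `CCCN(CCC)Cc1cccc(C(=O)OCCOCn2cnc3c(=O)[nH]c(N)nc32)c1` gives 0.0133 h, the lowest of the three; its gap to compound 3 and its far larger gap to compound 1 both lie beyond the scatter, so compound 2 is the shortest-lived of the measured set.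

Compound 4 `CCCCN(CCCC)Cc1cccc(C(=O)OCCOCn2cnc3c(=O)[nH]c(N)nc32)c1` is the next member and has not yet been run. Against compound 2 the change is: dibutylamino in place of dipropylamino on a saturated chain carbon bound to an aromatic carbon. Among the compounds with values here, no pair of measured compounds shows a change of this kind, so nothing measured speaks directly to its size; the shared core is unchanged. The expectation for compound 4 is a step of a 1.1-fold higher number from compound 2 to compound 4 (0.05 log units; within the scatter) that stays within the scatter. In this assay compound 4 is therefore expected at 0.015 h, with a range from 0.006 h to 0.04 h, because compound 2 gives 0.0133 h and the core it shares with compound 4 is the same.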

Compound 4, half-life: 0.0383 h
Compound 4: the middle estimate sits 2.6-fold (0.41 log units) below what was measured, within the range that was stated.
By their numbers in this assay, from the lowest: compound 2; then compounds 3 and 4 (each within the scatter of the next); then compound 1.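

In this assay, dibutylamino in place of dipropylamino on a saturated chain carbon bound to an aromatic carbon gives a 2.9-fold higher number from compound 2 to compound 4 (0.46 log units; beyond the scatter) on an unchanged shared core. Within the data shown here, this is the first matched step, and it shows that a change confined to this amine can move the half-life beyond the scatter. Nothing available bears on the reason for the step.

One pair gives the direction of this change only and sets no trend with chain length. As far as these compounds go, it remains open whether diethylamino, dipentylamino or a ring amine such as piperidinyl on the same chain carbon would extend, flatten or reverse the step, and whether dibutylamino in place of dipropylamino would give a similar step on a different core.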